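Piperidin-1-yl in place of pyrrolidin-1-yl

This account rests on a few compounds, and the source may have more. Where it says the series, first, only, none or still open, it means among the compounds named here.

In a functional assay on DU-145 cells (Homo sapiens) for inhibition, read by MTT assay, with stated times of 18 h and 4 h (a higher number here means a weaker inhibitor, a lower number a stronger inhibitor), compound 1 `CCCCCCCCCCOP(=O)(O)OCCSC(=S)N1CCCCCC1` gives 24000 nM and compound 3 `CCCCCCCCCCOP(=O)(O)OCCSC(=S)N1CCCC1` gives 46100 nM. Among the measured compounds shown here, these are the only two numerical values so far, and they lie within the scatter of each other, so compound 3 has compound 1 as its nearest neighbour and is not separated from it. Compound 2 `CCCOP(=O)(O)OCCSC(=S)N1CCCCC1` is recorded only as a limit, > 100000 nM.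

Compound 4 `CCCCCCCCCCOP(=O)(O)OCCSC(=S)N1CCCCC1` differs from compound 3 by a single change on a thiocarbonyl carbon: piperidin-1-yl in place of pyrrolidin-1-yl on a thiocarbonyl carbon. In words, piperidin-1-yl stands in place of pyrrolidin-1-yl. For the measured compounds named here, one measured step bears on this, the exchange of azepan-1-yl for pyrrolidin-1-yl at that same place, which gave a 1.9-fold higher number from compound 1 to compound 3 (0.28 log units; within the scatter). With that step inside the scatter, a further exchange at this place is expected to produce no clear shift in this assay. The estimated change is a 1.4-fold lower number from compound 3 to compound 4 (0.15 log units; within the scatter), which stays within the scatter. For compound 4 the estimate is 33000 nM, with an expected range from 15000 nM to 70000 nM.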

Compound 4, half-maximal inhibitory concentration: 29300 nM
For compound 4 the middle estimate is 1.1-fold (0.05 log units) above the measured one; measured number inside the range.
By their numbers in this assay, from the lowest: compounds 1, 4 and 3 (each within the scatter of the next). At a limit, above all of these: compound 2.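

In this assay, piperidin-1-yl on a thiocarbonyl carbon cannot be told apart from the two other rings at that place, with a 1.6-fold lower number from compound 3 to compound 4 (0.20 log units; within the scatter) and a 1.2-fold higher number from compound 1 to compound 4 (0.09 log units; within the scatter), so pyrrolidin-1-yl, piperidin-1-yl and azepan-1-yl now form a series without a separated member. Among the compounds shown here, compound 4 also opens a comparison at a second place, where heptyl in place of hydrogen on a saturated chain carbon gives an at least 3.4-fold lower number from compound 2 to compound 4 (0.53 log units; beyond the scatter), the only step here beyond the scatter. The value of compound 2 is a limit and not a number, so this step has no upper end: the limit of > 100000 nM in this assay, at which 1 of the 4 values shown sits.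

From the compounds shown here alone, whether morpholin-4-yl or an open-chain diethylamino group on the thiocarbonyl carbon would stay within the scatter of these rings remains open. So does how the number moves with a chain of intermediate length, or with a longer chain, on the shared core.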